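The source may hold more compounds than are shown below. What is called first, only, known or untested is meant among the compounds shown, and "the series" means these compounds.

In a functional assay on A549 cells (Homo sapiens) for antiproliferative activity, read by MTT assay, with a stated time of 72 h (on this read-out lower numbers stand for stronger inhibition and higher numbers for weaker inhibition), compound 1 `NC1=NC2(CCSCC2)N(OCCCOc2cccc(Cl)c2)C(N)=N1` gives 60 nM, the lowest number of the three measured compounds. Compound 2 `NC1=NC2(CCOCC2)N(OCCCOc2ccc(Cl)cc2)C(N)=N1` gives 360 nM, and compound 3 `NC1=NC2(CCOCC2)N(OCCCOc2ccc(F)cc2)C(N)=N1` gives 1060 nM. Compound 4 `NC1=NC2(CCSCC2)N(OCCCOc2cccc(Cl)c2Cl)C(N)=N1` keeps the core of compound 1 but changes 3-chlorophenyl to 2,3-dichlorophenyl, with chloro in place of hydrogen on an aromatic carbon, ortho to a chloro group: chloro in place of hydrogen on an aromatic carbon. Among the compounds with values here, no measured step makes this exact change. The closest evidence is indirect: a 2.9-fold higher number from compound 2 to compound 3 (0.47 log units; beyond the scatter), where the chloro compound has the lower number. A small step toward a lower number is therefore expected, a 1.5-fold lower number from compound 1 to compound 4 (0.18 log units; within the scatter), probably within the scatter. For compound 4 the estimate is 40 nM, with an expected range of 13 nM to 120 nM.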

Compound 4, half-maximal inhibitory concentration: 1 nM
Compound 4: the middle estimate sits 40-fold (1.60 log units) above what was measured; measured number outside the range, below it.
By their numbers in this assay, from the lowest: compound 4; then compound 1; then compound 2; then compound 3.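

In this assay, within the data shown here, the change from 3-chlorophenyl to 2,3-dichlorophenyl gives a 60-fold lower number from compound 1 to compound 4 (1.78 log units; beyond the scatter), a large step, whereas the only earlier step, a 2.9-fold higher number from compound 2 to compound 3 (0.47 log units; beyond the scatter), was modest. It shows that a single chloro in place of hydrogen, on an aromatic carbon ortho to a chloro group, can move the number strongly on the core of compound 1. Nothing measured here accounts for a step of this size. The compounds shown leave open whether fluoro, methyl or methoxy at this place would give a similar step. Going by these compounds, whether the same chloro addition does so on the core of compound 2 also remains open.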